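This account rests on a few compounds, and the source may have more. Where it says the series, first, only, none or still open, it means among the compounds named here.

Compound 3 `Cc1n[nH]c(C)c1CN1CCN(c2cccc3[nH]c(-c4ccc(C(C)(C)C)cc4)nc23)CC1` gives 68 nM in an assay on isolated protein for displacement of a labelled ligand from Gonadotropin-releasing hormone receptor (Homo sapiens) (on this read-out higher numbers stand for weaker inhibition and lower numbers for stronger inhibition), and stands second highest of the three numbers: compound 1 `Cc1ccc(CN2CCN(c3cccc4[nH]c(-c5ccc(C(C)(C)C)cc5)nc34)CC2)o1` gives 705 nM and compound 2 `Cc1nc(CN2CCN(c3cccc4[nH]c(-c5ccc(C(C)(C)C)cc5)nc34)CC2)c[nH]1` gives 7.5 nM. Compound 4 `CCCn1cnc(CN2CCN(c3cccc4[nH]c(-c5ccc(C(C)(C)C)cc5)nc34)CC2)c1C` carries 5-methyl-1-propyl-1H-imidazol-4-yl in place of 3,5-dimethyl-1H-pyrazol-4-yl on a saturated chain carbon bound to an amine nitrogen in a ring. Going by the values given here, three steps bear on this exchange, all moving the same group on the same chain carbon: a 94-fold lower number from compound 1 to compound 2 (1.97 log units; beyond the scatter), a 10-fold lower number from compound 1 to compound 3 (1.02 log units; beyond the scatter) and a 9.1-fold higher number from compound 2 to compound 3 (0.96 log units; beyond the scatter). The imidazole of compound 2 sits lowest among them; compound 4 returns to an imidazole, now as 5-methyl-1-propyl-1H-imidazol-4-yl, and the number of compound 2 marks the lowest seen. The expected step for compound 4 is a 3.4-fold lower number from compound 3 to compound 4 (0.53 log units; beyond the scatter), downward beyond the scatter. Compound 4 is estimated at 20 nM, range 5 nM to 80 nM.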

Compound 4, half-maximal inhibitory concentration: 12 nM
Compound 4: the middle estimate sits 1.7-fold (0.22 log units) above what was measured, within the range that was stated.
By their numbers in this assay, from the lowest: compounds 2 and 4 (each within the scatter of the next); then compound 3; then compound 1.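

The 5-methyl-1-propyl-1H-imidazol-4-yl group, with 0 hydrogen-bond donors, still gives (a 5.7-fold lower number from compound 3 to compound 4 (0.75 log units; beyond the scatter)), so a donor in the group on this chain carbon is not required for a low number. The two imidazoles cannot be told apart (a 1.6-fold higher number from compound 2 to compound 4 (0.20 log units; within the scatter)), so this position accepts the propyl group. The gain over the furan also holds for this imidazole (a 59-fold lower number from compound 1 to compound 4 (1.77 log units; beyond the scatter)).

Still open, going by these compounds, is whether a longer chain than propyl, or an amine at its end, would be accepted on the imidazole nitrogen. Nothing shown here gives a reason for these steps.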